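Trading a Methyl for a Cyano Group

The source may hold more compounds than are shown below. What is called first, only, known or untested is meant among the compounds shown, and "the series" means these compounds.

Compound 3 `Cc1cc(C)c(Oc2ccc(N)c(Nc3ccc(C#N)cc3)c2)c(C)c1` is one of three compounds tested in an ADME assay on H9 cells (Homo sapiens) for cytotoxicity, read by XTT assay, with a stated time of 6 days; a higher number here means that more compound is tolerated, a lower number that less compound is tolerated. In this assay compound 3 gives 51000 nM, one of two plain numbers among the three results. Compound 1 `Cc1cc(C)c(Oc2cc(Nc3ccc(C#N)cc3)c(N)cc2[N+](=O)[O-])c(C)c1` gives 32200 nM in this assay, within the usual scatter of compound 3. Compound 2 `Cc1cc(C#N)cc(C)c1Oc1ccc([N+](=O)[O-])c(Nc2ccc(C#N)cc2)c1` reaches only the limit > 65100 nM in this assay, a bound rather than a number, as the limit of > 65100 nM in this assay, at which 1 of the 3 values shown sits, notes. Among the measured compounds shown here, the one measured step, a 1.6-fold higher number from compound 1 to compound 3 (0.20 log units; within the scatter), alters a different part of the molecule. Compound 4 `Cc1cc(C#N)cc(C)c1Oc1ccc(N)c(Nc2ccc(C#N)cc2)c1` arises from compound 3 by cyano in place of methyl on an aromatic carbon. For the measured compounds named here, no measured step shows how a cyano in place of methyl shifts this assay; compound 2 carries that cyano but also differs from compound 3 elsewhere. The step expected is therefore small, a 1.2-fold higher number from compound 3 to compound 4 (0.07 log units; within the scatter). Compound 4 is estimated at 60000 nM, from 30000 nM to 120000 nM.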

Compound 4, half-maximal cytotoxic concentration: 49800 nM
Estimate against measurement, compound 4: 1.2-fold (0.08 log units) above; the measured number falls inside the stated range.
By their numbers in this assay, from the lowest: compounds 1, 4 and 3 (each within the scatter of the next). At a limit, above all of these: compound 2.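

In this assay, cyano in place of methyl now has a measured step of its own, a 1.0-fold lower number from compound 3 to compound 4 (0.01 log units; within the scatter), so on this aromatic carbon, para to a large group, the exchange leaves the number within the scatter. Amino in place of nitro on an aromatic carbon gives an at least 1.3-fold lower number from compound 2 to compound 4 (0.11 log units; that floor lies within the scatter). The reading for compound 2 is a limit, not a number: the limit of > 65100 nM in this assay, at which 1 of the 4 values shown sits.

From the compounds shown here alone, whether a carboxylic acid or an amine on this aromatic carbon would also stay within the scatter of compound 3 remains open. So does the full size of the step between compound 2 and compound 4.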